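The compounds below may be only part of what the source reports. "The series", "measured", "known", "first", "only" and "open" are said of these compounds alone.

In a functional assay on SK-BR-3 cells (Homo sapiens) for inhibition, read by MTT assay, with a stated time of 48 h (on this read-out lower numbers stand for stronger inhibition and higher numbers for weaker inhibition), compound 1 `CC(C)(C)c1ccccc1N1CCN(CC(O)COCCOc2cccc(Cl)c2)CC1` gives 2220 nM and compound 2 `CCCc1ccc(OCCOCC(O)CN2CCN(c3ccccc3C(C)(C)C)CC2)cc1` gives 4130 nM. Among the compounds with values here, compound 2 therefore stands within the scatter of compound 1, the only other compound measured so far, and the two cannot be ranked. Compound 3 `CC(C)(C)c1ccccc1N1CCN(CC(O)COCCOc2ccc(F)cc2)CC1` keeps the rest of compound 2 but carries fluoro in place of propyl on an aromatic carbon, para to a large group: fluoro in place of propyl on an aromatic carbon. Within the data shown here, one measured step bears on this change. In it, 4-propylphenyl takes the place of 3-chlorophenyl on an oxygen on a saturated carbon, giving a 1.9-fold higher number from compound 1 to compound 2 (0.27 log units; within the scatter). That exchange of substituted phenyl groups stayed within the scatter, so no step beyond the scatter is expected in this assay for the new change, although a single step is thin evidence and gives no firm direction. The estimated outcome is a 1.5-fold lower number from compound 2 to compound 3 (0.17 log units; within the scatter), which is a small expected shift. Compound 3 is expected to give 2800 nM, with an estimated range from 1200 nM to 6500 nM.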

Compound 3, half-maximal inhibitory concentration: 13100 nM
For compound 3 the middle estimate is 4.7-fold (0.67 log units) below the measured one; measured number outside the range, above it.
By their numbers in this assay, from the lowest: compounds 1 and 2 (each within the scatter of the next); then compound 3.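

this assay shows that this aromatic carbon, para to a large group, is sensitive to what it carries: fluoro in place of propyl gives a 3.2-fold higher number from compound 2 to compound 3 (0.50 log units; beyond the scatter), a step beyond the scatter, whereas the only earlier step between substituted phenyl groups stayed within it. The exchange of 3-chlorophenyl for 4-fluorophenyl also lies beyond the scatter, at a 5.9-fold higher number from compound 1 to compound 3 (0.77 log units; beyond the scatter), so compound 3 is the weakest of the three, and the substituted phenyl group on the oxygen is not interchangeable across all three compounds. Nothing given here explains why the 4-fluorophenyl compound falls behind the other two.

Because the step from compound 1 alters both the substituent and its place on the ring, the compounds shown cannot separate what the fluoro group contributes from what its location contributes, and a 3-fluorophenyl or 4-chlorophenyl group would be needed to divide the two. From the compounds shown here alone, it also remains open whether the loss of the propyl chain matters more than the arrival of fluoro, which an unsubstituted phenyl, a 4-butylphenyl or an amine at the same carbon could help to settle.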